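This account rests on a few compounds, and the source may have more. Where it says the series, first, only, none or still open, it means among the compounds named here.

Two compounds of the series carry a number in a functional assay on Raji cells (Homo sapiens) for inhibition, read by MTT assay, with a stated time of 72 h; on this read-out lower numbers stand for stronger inhibition and higher numbers for weaker inhibition. Compound 1 `O=C1C[C@H]2O[C@H]([C@H](O)c3ccccc3)[C@H](O)[C@H]2O1` gives 18500 nM in this assay, and compound 2 `CO[C@H](c1ccccc1)[C@H]1O[C@@H]2CC(=O)O[C@@H]2[C@H]1O` gives 15600 nM. Going by the values given here, the single step between them, a 1.2-fold lower number from compound 1 to compound 2 (0.07 log units; within the scatter), is the only measured step so far. Compound 2 therefore stands at 15600 nM in this assay, within the scatter of compound 1; no order can be read into the two numbers.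

Compound 3 `CO[C@@H]1[C@H]2OC(=O)C[C@H]2O[C@@H]1[C@H](OC)c1ccccc1` is the next member and differs from compound 2 by methyl in place of hydrogen on an oxygen on a saturated carbon. Among the compounds with values here, the only measured step that bears on this change is a 1.2-fold lower number from compound 1 to compound 2 (0.07 log units; within the scatter), which involves the same kind of exchange, methyl in place of hydrogen on an oxygen on a saturated carbon, and stayed within the scatter. On that basis no step beyond the scatter is expected from compound 2 to compound 3 in this assay, and the expected shift is a 1.1-fold lower number from compound 2 to compound 3 (0.05 log units; within the scatter). For compound 3 the estimated value in this assay is 14000 nM, with a range from 6000 nM to 32000 nM. Whether the second methyl behaves like the first remains to be measured.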

Compound 3, half-maximal inhibitory concentration: 12400 nM
Compound 3: the middle estimate sits 1.1-fold (0.05 log units) above what was measured; low and high end bracket the measured number.
By their numbers in this assay, from the lowest: compounds 3, 2 and 1 (each within the scatter of the next).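

The exchange of hydroxy to methoxy now also stands on an oxygen on a saturated carbon whose other neighbours are: saturated ring carbon, and in this assay it gives a 1.3-fold lower number from compound 2 to compound 3 (0.10 log units; within the scatter), so this place too shows no step beyond the scatter. Compound 3 carries no free hydroxy and compound 3 gives 12400 nM, so a free hydroxy at this place is not needed to keep the number within the scatter of compound 2, and the exchange has now stayed within the scatter in both places where it was read, the other being a 1.2-fold lower number from compound 1 to compound 2 (0.07 log units; within the scatter). Nothing shown here offers an explanation for the size of this step.

The compounds shown leave open whether anything larger than methyl on this oxygen, such as ethyl, a longer chain or benzyl, would give a step beyond the scatter. They also leave open what an acetyl ester or an amine at the same place would do, and whether any change at this place can separate a compound from the others in this assay.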